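Thiadiazole Amide in a Free Fatty Acid Receptor 2 Series

The compounds below may be only part of what the source reports. "The series", "measured", "known", "first", "only" and "open" are said of these compounds alone.

Compound 2 `CC(C)[C@H](C(=O)Nc1ccc(F)cn1)c1ccc(Cl)cc1` stands highest of the two compounds measured in a functional assay on CHO cells for agonist activity at Free fatty acid receptor 2 (Homo sapiens), read by cAMP accumulation (a lower number here means a smaller maximal response, a higher number a larger maximal response), where compound 2 gives 93%. Its neighbour, compound 1 `CNC(=O)[C@H](c1ccc(Cl)cc1)C(C)C`, gives 66% in this assay; the step of a number 27 percentage points higher from compound 1 to compound 2 (beyond the scatter) is modest and beyond the scatter. Compound 3 `CC(C)[C@H](C(=O)Nc1nncs1)c1ccc(Cl)cc1` is not yet measured. It differs from compound 2 as follows: 1,3,4-thiadiazol-2-yl in place of 5-fluoropyridin-2-yl on an amide-type nitrogen. For the measured compounds named here, the one measured step bears on this change only loosely, since it put 5-fluoropyridin-2-yl in place of methyl on the same amide-type nitrogen, whereas here one aromatic ring replaces another. Nothing shows how a five-membered ring with three hetero atoms behaves at that place. The expected outcome is therefore a step of a number 8 percentage points lower from compound 2 to compound 3 (within the scatter) that stays close to compound 2, within the scatter, with a wide range to allow a decline. Compound 3 is estimated to give 85% in this assay, in the range 62% to 102%.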

Compound 3, largest response reached (reported as efficacy), in percent of the reference or control that the assay uses: 115%
The estimate for compound 3 lay 30 percentage points below the measured number; measured number above the stated range.
By their numbers in this assay, from the lowest: compound 1; then compound 2; then compound 3.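

At the amide-type nitrogen, one aromatic ring cannot simply stand in for another: in this assay, 1,3,4-thiadiazol-2-yl in place of 5-fluoropyridin-2-yl gives a number 22 percentage points higher from compound 2 to compound 3 (beyond the scatter) and so shows that the response depends on which ring sits there, which the earlier change from methyl could not reveal. Measured against methyl, the thiadiazole gives a number 49 percentage points higher from compound 1 to compound 3 (beyond the scatter) and places compound 3 beyond the scatter of both other compounds, so the top of this small set now lies above the fluoropyridine. No measurement here accounts for the difference between the two rings.

The three compounds leave open whether the higher response goes with the sulfur of the ring or with its nitrogens, a question that 1,3,4-oxadiazol-2-yl on the same nitrogen would address. On these data alone, how far the result carries over to changes elsewhere in the shared core also remains open.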